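Removing One Aromatic Methyl From Compound 2

The source may hold more compounds than are shown below. What is called first, only, known or untested is meant among the compounds shown, and "the series" means these compounds.

- compound 1 (`CC(C)=CCC/C(C)=C/CC/C(C)=C/CC[C@]1(C)CCc2cc(OC(=O)c3ccc(C(=O)O)cc3C(=O)O)c(C)c(C)c2O1`) with 620 nM measured
- compound 2 (`CC(C)=CCC/C(C)=C/CC/C(C)=C/CC[C@]1(C)CCc2c(C)c(OC(=O)c3cc(C(=O)O)ccc3C(=O)O)c(C)c(C)c2O1`) with 1460 nM measured

In a functional assay on cells (+SA cell, Mus musculus) for cytotoxicity, read by MTT assay, with a stated time of 24 h (on this read-out lower numbers stand for stronger inhibition and higher numbers for weaker inhibition), compound 2 gives 1460 nM as the higher of the two numbers, and compound 1 stands clearly lower at 620 nM in the same test. Compound 3 (`CC(C)=CCC/C(C)=C/CC/C(C)=C/CC[C@]1(C)CCc2cc(OC(=O)c3cc(C(=O)O)ccc3C(=O)O)c(C)c(C)c2O1`) differs from compound 2 by having hydrogen in place of methyl on an aromatic carbon and has not been measured. Among the compounds with values here, no measured pair shows this single change alone, so the only guide is the gap between those two values. The expected move is small and downward, an estimated 1.7-fold lower number from compound 2 to compound 3 (0.23 log units; within the scatter) in this assay, perhaps no larger than the scatter. For compound 3 the estimated value is 850 nM (expected range 350 nM to 2000 nM).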

Compound 3, half-maximal inhibitory concentration: 1440 nM
Compound 3: middle estimate off by 1.7-fold (0.23 log units), on the low side, within the range that was stated.
By their numbers in this assay, from the lowest: compound 1; then compounds 3 and 2 (each within the scatter of the next).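

In this assay, hydrogen in place of methyl on an aromatic carbon gives a 1.0-fold lower number from compound 2 to compound 3 (0.01 log units; within the scatter), so compound 2 and compound 3 cannot be told apart and this methyl shows no measurable contribution here. The earlier gap instead follows the acid pattern: 2,5-dicarboxyphenyl in place of 2,4-dicarboxyphenyl on a carbonyl carbon gives a 2.3-fold higher number from compound 1 to compound 3 (0.37 log units; beyond the scatter). No supporting measurement explains either result. On these data alone, whether an ethyl or methoxy group on this aromatic carbon would behave like methyl remains open, as does the effect of an amine in place of either carboxylic acid.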